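One more hydroxymethyl on the side chain of compound 2

This account rests on a few compounds, and the source may have more. Where it says the series, first, only, none or still open, it means among the compounds named here.

In a functional assay on HepG2 cells (Homo sapiens) for inhibition, read by CCK-8 assay, with a stated time of 72 h (on this read-out lower numbers stand for stronger inhibition and higher numbers for weaker inhibition), compound 1 (`C[C@H]1O[C@@H]2C[C@@H](O)[C@@]1(O)c1c2c(O)c(C(N)=O)c2ncoc12`) gives 12400 nM. Compound 2 (`C[C@H]1O[C@@H]2C[C@@H](O)[C@@]1(O)c1c2c(O)c(C(N)=O)c2nc([C@@H](O)CO)oc12`), which carries 1,2-dihydroxyethyl in place of hydrogen on an aromatic carbon, gives 8900 nM, so the two compounds stand within the scatter of each other.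

Compound 3 (`C[C@H]1O[C@@H]2C[C@@H](O)[C@@]1(O)c1c2c(O)c(C(N)=O)c2nc([C@@H](O)[C@@H](O)CO)oc12`) differs from compound 2 by hydroxymethyl in place of hydrogen on a saturated chain carbon bound to an oxygen on a saturated carbon and a saturated chain carbon. This places hydroxymethyl in place of hydrogen on a saturated chain carbon bound to an oxygen on a saturated carbon and a saturated chain carbon, turning 1,2-dihydroxyethyl into 1,2,3-trihydroxypropyl.

Within the data shown here, only one measured step bears on this change: a 1.4-fold lower number from compound 1 to compound 2 (0.14 log units; within the scatter). That step introduced the chain now being lengthened, and it did not leave the scatter. A single step is thin evidence, but it gives no ground for expecting a move in either direction in this assay. The expected step, which should stay within the scatter, is a 1.0-fold lower number from compound 2 to compound 3 (0.02 log units; within the scatter). For compound 3 the estimated value is 8500 nM, with an expected range of 3500 nM to 20000 nM.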

Compound 3, half-maximal inhibitory concentration: 5600 nM
Beside the measured number, compound 3's estimate is 1.5-fold (0.18 log units) above it; low and high end bracket the measured number.
By their numbers in this assay, from the lowest: compounds 3, 2 and 1 (each within the scatter of the next, the first and the last beyond it).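

In this assay, a 1.6-fold lower number from compound 2 to compound 3 (0.20 log units; within the scatter) stays within the scatter, so the added hydroxymethyl, which turns 1,2-dihydroxyethyl into 1,2,3-trihydroxypropyl, cannot be read as a change on its own. The whole substituent gives a clearer reading: with 1,2,3-trihydroxypropyl in place of hydrogen on an aromatic carbon, a 2.2-fold lower number from compound 1 to compound 3 (0.35 log units; beyond the scatter) is the first step among these compounds to pass beyond the scatter, though only modestly. Compound 2 lies within the scatter of both compound 1 and compound 3, so the series supports a small overall difference between its two ends, not a graded trend with each added hydroxymethyl. Nothing at hand gives a measured reason for this difference.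

As far as these compounds go, it remains open whether a longer chain, such as 1,2,3,4-tetrahydroxybutyl, would lower the number in this assay any further or would leave it within the scatter of compound 3. From the compounds shown here alone, it is also open how a plain propyl chain, an amine or a carboxylic acid would read in place of 1,2,3-trihydroxypropyl on the same aromatic carbon.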